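The source may hold more compounds than are shown below. What is called first, only, known or untested is meant among the compounds shown, and "the series" means these compounds.

Working notes on the series, read in a functional assay on DU-145 cells (Homo sapiens) for inhibition, read by trypan blue exclusion, with a stated time of 96 h; a lower number here means a stronger inhibitor of growth, a higher number a weaker inhibitor of growth. Compound 1 (`O=C(/C(=C\c1ccc(F)c([N+](=O)[O-])c1)S(=O)(=O)c1ccc(Br)cc1)c1ccc(Br)cc1`) gives 25000 nM, compound 2 (`COc1ccc(/C=C(\C(=O)c2ccc(Br)cc2)S(=O)(=O)c2ccc(Br)cc2)c(F)c1`) gives 10000 nM and compound 3 (`O=C(/C(=C\c1ccc(F)cc1F)S(=O)(=O)c1ccc(Br)cc1)c1ccc(Br)cc1`) gives 7500 nM. Compound 3 cannot be separated from compound 2, with a 1.3-fold lower number from compound 2 to compound 3 (0.12 log units; within the scatter). It is clearly separated from compound 1, with a 3.3-fold lower number from compound 1 to compound 3 (0.52 log units; beyond the scatter).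

The next structure is compound 4 (`O=C(/C(=C\c1c[nH]c2ccccc12)S(=O)(=O)c1ccc(Br)cc1)c1ccc(Br)cc1`). The change is 1H-indol-3-yl in place of 2,4-difluorophenyl on a double-bonded chain carbon bound to a double-bonded chain carbon, so 1H-indol-3-yl stands in place of 2,4-difluorophenyl on a double-bonded chain carbon bound to a double-bonded chain carbon.

The three measured steps all change the group at this same place. Two are modest, a 2.5-fold lower number from compound 1 to compound 2 (0.40 log units; beyond the scatter) and a 3.3-fold lower number from compound 1 to compound 3 (0.52 log units; beyond the scatter), and the third, a 1.3-fold lower number from compound 2 to compound 3 (0.12 log units; within the scatter), stays within the scatter. None of them brings in a five-membered aromatic ring, so the direction in this assay is poorly supported and the range has to stay wide on both sides. The estimated step is a 1.3-fold higher number from compound 3 to compound 4 (0.12 log units; within the scatter), so no shift beyond the scatter is expected. For compound 4 the expected value is 10000 nM, with an estimated range of 3000 nM to 30000 nM.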

Compound 4, concentration for 50% growth inhibition: 25000 nM
Estimate against measurement, compound 4: 2.5-fold (0.40 log units) below; the range from low to high includes it.
By their numbers in this assay, from the lowest: compounds 3 and 2 (each within the scatter of the next); then compounds 1 and 4 (each within the scatter of the next).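

In this assay this position now carries a group with a five-membered aromatic ring, and 1H-indol-3-yl reads weaker than both 2,4-difluorophenyl and 2-fluoro-4-methoxyphenyl, with a 3.3-fold higher number from compound 3 to compound 4 (0.52 log units; beyond the scatter) and a 2.5-fold higher number from compound 2 to compound 4 (0.40 log units; beyond the scatter). Against 4-fluoro-3-nitrophenyl it cannot be separated, with no change at the digits printed from compound 1 to compound 4 (within the scatter), so two very different groups share the weak end of the series. Nothing available bears on why the number moves with this change.

Going by these compounds, it stays open whether the higher number goes with the five-membered ring, the hydrogen-bond donor or the loss of the fluoro groups, as this single change alters all three together. On these data alone, it is also open how a phenyl carrying an amine or a carboxylic acid at this place would read, and whether any group here can improve on compound 3 at 7500 nM.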